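This account rests on a few compounds, and the source may have more. Where it says the series, first, only, none or still open, it means among the compounds named here.

Within the data shown here, compound 1 `Cc1ccc(C(CCN(C)C)NC(=O)CCc2ccccc2)cc1` is the weaker of the two compounds measured so far in a functional assay on NIH3T3 cells for agonist activity at Urotensin-2 receptor (Homo sapiens), with a stated time of 5 days; on this read-out lower numbers stand for an effect already at smaller amounts and higher numbers for an effect only at larger amounts of compound: compound 1 gives 4570 nM, the highest of the two numbers, while its nearest neighbour compound 2 `Cc1ccc(C(CCN(C)C)NC(=O)CCc2ccc(C(F)(F)F)cc2)cc1` gives 2290 nM, a step of a 2.0-fold lower number from compound 1 to compound 2 (0.30 log units; within the scatter) that stays within the scatter of the assay. Compound 3 `CN(C)CCC(NC(=O)CCc1ccccc1)c1ccc(Cl)cc1` has not yet been measured. It differs from compound 1 in one place: chloro in place of methyl on an aromatic carbon. Among the measured compounds shown here, no measured pair addresses this change directly. For the measured compounds named here, the only step on record, from compound 1 to compound 2, concerns a substituent on the other aromatic ring, and a 2.0-fold lower number from compound 1 to compound 2 (0.30 log units; within the scatter) there was within the scatter, which gives no ground to expect a large movement from an exchange of one small aromatic substituent for another. Compound 3 is therefore expected to sit close to compound 1, with a step of a 1.1-fold lower number from compound 1 to compound 3 (0.06 log units; within the scatter) that is not expected to exceed the scatter in either direction. For compound 3 the expected value in this assay is 4000 nM, estimated to lie between 1500 nM and 12000 nM.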

Compound 3, half-maximal effective concentration: 1660 nM
Compound 3: the middle estimate sits 2.4-fold (0.38 log units) above what was measured; low and high end bracket the measured number.
By their numbers in this assay, from the lowest: compounds 3, 2 and 1 (each within the scatter of the next, the first and the last beyond it).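

Among these compounds, the exchange of 4-methylphenyl for 4-chlorophenyl gives the first step in this assay that goes beyond the scatter, though only modestly: a 2.8-fold lower number from compound 1 to compound 3 (0.44 log units; beyond the scatter). This shows that the number responds to what stands on this aromatic carbon, para to a large group, even though methyl and chloro each count one heavy atom, with no hydrogen-bond donors or acceptors and no net charge, whereas the earlier change on the other aromatic ring, a 2.0-fold lower number from compound 1 to compound 2 (0.30 log units; within the scatter), stayed within the scatter. The data shown offer no measured explanation for this shift.

Going by these compounds, it remains open whether the lower number is specific to chloro or would also appear with another group at this place, such as fluoro, bromo, methoxy or trifluoromethyl. Also open, on these data alone, are whether chloro and the trifluoromethyl on the other aromatic ring would act together in one compound, and how the number would respond if the dimethylamino group gave way to a primary amine or the chain carrying it were longer.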